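Swapping a pyrrole for a substituted phenyl on a hydrazone

The source may report more compounds than this note shows. Statements on the series, on what has been measured and on what is new or still open speak of the compounds shown alone.

Of the compounds shown here, three sharing one core have been measured in an assay on CHO-K1 cells for displacement of a labelled ligand from adenosine receptor A1 (Homo sapiens), read by scintillation counting, with a stated time of 60 min; on this read-out higher numbers stand for weaker inhibition and lower numbers for stronger inhibition. Compound 1 `CCCCC/C=C/C=C/C=N/Nc1nc(N)c2ncn([C@@H]3O[C@H](CO)[C@@H](O)[C@H]3O)c2n1` gives 2 nM. Compound 2 `CCOc1cc(/C=N/Nc2nc(N)c3ncn([C@@H]4O[C@H](CO)[C@@H](O)[C@H]4O)c3n2)ccc1O` gives 6940 nM. Compound 3 `Nc1nc(N/N=C/c2ccc[nH]2)nc2c1ncn2[C@@H]1O[C@H](CO)[C@@H](O)[C@H]1O` gives 8 nM, which places it second highest of the three numbers: nearest to compound 1, with a 4.0-fold higher number from compound 1 to compound 3 (0.60 log units; beyond the scatter), and far from compound 2, with an 870-fold lower number from compound 2 to compound 3 (2.94 log units; beyond the scatter).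

Compound 4 `Nc1nc(N/N=C/c2ccc(Cl)c(C(F)(F)F)c2)nc2c1ncn2[C@@H]1O[C@H](CO)[C@@H](O)[C@H]1O` has not yet been measured in this assay. It differs from compound 3 in one place: 4-chloro-3-(trifluoromethyl)phenyl in place of 1H-pyrrol-2-yl on a carbon with a double bond to nitrogen. For the measured compounds named here, the only measured comparison that bears on this change is the one in which a six-membered aromatic ring of carbon only stood on the same carbon, and there the number was large, with a 3500-fold higher number from compound 1 to compound 2 (3.54 log units; beyond the scatter) and an 870-fold lower number from compound 2 to compound 3 (2.94 log units; beyond the scatter). That six-membered ring carried ethoxy and hydroxy groups, whereas the ring entering compound 4 carries chloro and trifluoromethyl, so the comparison is imperfect. A large step towards a higher number is nevertheless expected, a 63-fold higher number from compound 3 to compound 4 (1.80 log units; beyond the scatter), giving compound 4 an estimated 500 nM, within a range from 50 nM to 5000 nM.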

Compound 4, inhibition constant: > 10000 nM
Compound 4 gave a limit, no number (the forecaster's own chance of this, stated with the estimate: 5%); at least 20-fold (1.30 log units) between middle value and limit.
By their numbers in this assay, from the lowest: compound 1; then compound 3; then compound 2. At a limit, above all of these: compound 4.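

Compound 4 gives no number, only a limit: the limit of > 10000 nM in this assay, at which 1 of the 4 values shown sits.

With 4-chloro-3-(trifluoromethyl)phenyl in place of 1H-pyrrol-2-yl on this carbon, the result is an at least 1200-fold higher number from compound 3 to compound 4 (3.09 log units; beyond the scatter), and the comparison with the chain of compound 1 gives an at least 5000-fold higher number from compound 1 to compound 4 (3.69 log units; beyond the scatter). High numbers on this carbon are therefore not confined to the ethoxy and hydroxy ring of compound 2, although the two phenyl compounds cannot be ranked against each other, as the step is only an at least 1.4-fold higher number from compound 2 to compound 4 (0.15 log units; that floor lies within the scatter).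

Both measured six-membered rings carry groups, so the compounds shown leave open whether the ring itself or those groups drive the change, a question that a plain phenyl would address. Going by these compounds, how a phenyl bearing an amine or a carboxylic acid would behave also remains open.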